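A few compounds are considered here, and "the series" means these few. Any claim that something is new, unique, unknown or untested is made for them only; others in the source may bear on it.

Three compounds of a shared core, compound 1 `O=C(O)c1ccc2noc(-c3ccc(-c4ccncc4)cc3)c2c1`, compound 2 `O=C(O)c1ccc2noc(-c3ccc(Oc4ccccn4)cc3)c2c1` and compound 3 `CC(C)NC(=O)c1ccc(-c2onc3ccc(C(=O)O)cc23)cc1`, have been measured in an assay for inhibition of inositol hexakisphosphate kinase 2 (Homo sapiens), read by colorimetric assay, coupled enzyme assay and malachite green, with a stated time of 120 min, in the presence of a further agent that is not named here; a lower number here means a stronger inhibitor, a higher number a weaker inhibitor. Compound 1 gives 150 nM, compound 2 gives 1190 nM, and compound 3 gives 350 nM. On these numbers compound 3 stands second highest of the three: the step of a 2.3-fold higher number from compound 1 to compound 3 (0.37 log units; beyond the scatter) puts it beyond the scatter from compound 1, and the step of a 3.4-fold lower number from compound 2 to compound 3 (0.53 log units; beyond the scatter) sets it beyond the scatter from compound 2 in the other direction.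

Compound 4 `O=C(O)c1ccc2noc(-c3ccc(NC(=O)c4ccncn4)cc3)c2c1` differs from compound 3 in one place: ((pyrimidin-4-yl)carbonyl)amino in place of isopropylcarbamoyl on an aromatic carbon. Within the data shown here, the steps that bear on this are those around compound 3, the step of a 2.3-fold higher number from compound 1 to compound 3 (0.37 log units; beyond the scatter), where an aromatic heterocycle gave way to isopropylcarbamoyl, and the step of a 3.4-fold lower number from compound 2 to compound 3 (0.53 log units; beyond the scatter). The change to compound 4 restores a six-membered aromatic ring with hetero atoms at this position, which resembles compound 1 more than compound 2, so a modest step toward a lower number is expected. Compound 4 is therefore estimated at 250 nM in this assay, within 80 nM to 800 nM, a step of a 1.4-fold lower number from compound 3 to compound 4 (0.15 log units; within the scatter) that is expected to stay near the scatter.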

Compound 4, half-maximal inhibitory concentration: 720 nM
For compound 4 the middle estimate is 2.9-fold (0.46 log units) below the measured one, within the range that was stated.
By their numbers in this assay, from the lowest: compound 1; then compound 3; then compounds 4 and 2 (each within the scatter of the next).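

In this assay, a six-membered aromatic ring with 2 hetero atoms at this position does not by itself keep the number of compound 1: ((pyrimidin-4-yl)carbonyl)amino in place of pyridin-4-yl gives (a 4.8-fold higher number from compound 1 to compound 4 (0.68 log units; beyond the scatter)), and compound 1 remains the lowest of the four. Larger size and more hydrogen-bond acceptors than isopropylcarbamoyl brought no gain here, the exchange giving (a 2.1-fold higher number from compound 3 to compound 4 (0.31 log units; beyond the scatter)), while the comparison with (pyridin-2-yl)oxy stays unresolved (a 1.7-fold lower number from compound 2 to compound 4 (0.22 log units; within the scatter)). Nothing available explains why these groups differ.

The compounds shown leave open whether the pyrimidin-4-yl ring or the carbonylamino link accounts for the loss from compound 1. Going by these compounds, a (pyridin-4-yl)carbonylamino group or a directly attached pyrimidin-4-yl ring would separate the two, and a plain amine at this position remains untested in this set.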